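Amino in Place of Chloro: A Second Instance Expected

This account rests on a few compounds, and the source may have more. Where it says the series, first, only, none or still open, it means among the compounds named here.

Compound 1 `ClCc1ccccc1Cn1cnc2c(Cl)nc(Cl)nc21` and compound 2 `ClCc1cccc(Cn2cnc3c(Cl)nc(Cl)nc32)c1` have the same atoms joined differently; the difference between the two cores is not broken down here. In a functional assay on TK-10 cells (Homo sapiens) for cytotoxicity, read by sulforhodamine B assay, with a stated time of 48 h (a lower number here means a stronger inhibitor of growth, a higher number a weaker inhibitor of growth), compound 1 gives 1450 nM and compound 2 gives 1730 nM, two numbers within the usual scatter of each other. Compound 3 `Nc1nc(Cl)c2ncn(Cc3ccccc3CCl)c2n1` carries the change amino in place of chloro on an aromatic carbon on the core of compound 1, and in this assay compound 3 gives 17800 nM, which is a 12-fold higher number from compound 1 to compound 3 (1.09 log units; beyond the scatter). Compound 4 `Nc1nc(Cl)c2ncn(Cc3cccc(CCl)c3)c2n1` carries the same kind of change amino in place of chloro on an aromatic carbon on the core of compound 2, and the surroundings of the place agree word for word with those of the earlier change. A step of a 12-fold higher number from compound 2 to compound 4 (1.08 log units; beyond the scatter) is therefore expected, resting on a 12-fold higher number from compound 1 to compound 3 (1.09 log units; beyond the scatter). Compound 4 is accordingly estimated at 21000 nM in this assay, between 9000 nM and 50000 nM.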

Compound 4, concentration for 50% growth inhibition: 2390 nM
Beside the measured number, compound 4's estimate is 8.8-fold (0.94 log units) above it; the whole stated range lies above it.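

On the core of compound 2, the change amino in place of chloro on an aromatic carbon gives a 1.4-fold higher number from compound 2 to compound 4 (0.14 log units; within the scatter) in this assay and stays within the scatter, whereas on the core of compound 1 the same change goes beyond it. The size of the step therefore did not carry from one core to the other, even though the surroundings of the place agree word for word: the same change on two cores in this assay, a 12-fold higher number (1.09 log units; beyond the scatter) from compound 1 to compound 3 and a 1.4-fold higher number (0.14 log units; within the scatter) from compound 2 to compound 4, 8.9-fold (0.95 log units) apart, beyond the scatter of two such steps

Going by these compounds alone, with only two pairs, this shows that the step can differ between cores, but it does not show which feature of the cores sets the size of the step.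

The compounds shown leave open how a methylamine or a methoxy group at this place would fare on the two cores. They also leave open what a hydroxymethyl group in place of the chloromethyl group would do.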